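This account rests on a few compounds, and the source may have more. Where it says the series, first, only, none or still open, it means among the compounds named here.

Measured compounds:
- compound 1, `O=C1C[C@@H]2O[C@@H](Cc3ccccc3)[C@@H](O)[C@@H]2O1`: 120 nM
- compound 2, `O=C1C[C@H]2O[C@H]([C@H](O)c3ccccc3)[C@H](O)[C@H]2O1`: 32500 nM
- compound 3, `O=C1C[C@@H]2O[C@H]3[C@H](c4ccccc4)c4ccccc4CO[C@H]3[C@@H]2O1`: 18500 nM

All three were tested in a functional assay on Jurkat cells (Homo sapiens) for antiproliferative activity, read by MTT assay, with a stated time of 72 h; on this read-out lower numbers stand for stronger inhibition and higher numbers for weaker inhibition. Compound 2 carries the highest number of the three, meaning the weakest inhibition of cell growth. Its nearest neighbour is compound 3, whose value in this assay is within the usual scatter of that of compound 2, so no order can be read into that pair. Compound 1, by contrast, gives a far lower number in this assay, a gap well beyond the scatter.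

Compound 4, `Cc1ccccc1[C@H](c1ccccc1)[C@H]1O[C@@H]2CC(=O)O[C@@H]2[C@H]1O`, has not yet been tested. It differs from compound 2 in one place: 2-methylphenyl in place of hydroxy on a saturated chain carbon bound to an aromatic carbon and a saturated ring carbon. In this assay, the expected step from compound 2 to compound 4 is an 8.1-fold lower number from compound 2 to compound 4 (0.91 log units; beyond the scatter), toward stronger inhibition, because compound 1, which also lacks the hydroxy group, gives 120 nM while compound 3, which carries two aromatic rings on the same chain carbon, gives 18500 nM, a value within the scatter of that of compound 2. Compound 4 is therefore estimated at 4000 nM, with a likely range from 600 nM to 25000 nM.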

Compound 4, half-maximal inhibitory concentration: 21400 nM
Beside the measured number, compound 4's estimate is 5.4-fold (0.73 log units) below it; low and high end bracket the measured number.
By their numbers in this assay, from the lowest: compound 1; then compounds 3, 4 and 2 (each within the scatter of the next).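

In this assay, putting 2-methylphenyl in place of hydroxy on the saturated chain carbon gives a 1.5-fold lower number from compound 2 to compound 4 (0.18 log units; within the scatter), so this swap shows no measurable effect on the number. Among the compounds shown here, this is the first pair here that differs in one place, and it shows that this carbon can exchange a single oxygen atom for seven carbon atoms and an extra aromatic ring, while losing a hydrogen-bond donor and acceptor, with the read-out staying within the scatter. No measurement at hand bears on why the number holds steady.

As far as these compounds go, whether an amine, a carboxylic acid or a longer chain on this carbon would shift the number remains open. From the compounds shown here alone, it is also open whether any group here can give a value beyond the scatter of that of compound 2.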